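The source may report more compounds than this note shows. Statements on the series, on what has been measured and on what is new or still open speak of the compounds shown alone.

Two compounds of this study share a core and were examined in a functional assay on CHO cells for antagonist activity at adenosine receptor A2b (Homo sapiens); on this read-out higher numbers stand for weaker inhibition and lower numbers for stronger inhibition. Compound 1, `CCCn1c(-c2ccco2)nc2c(N)ncnc21`, gives 250 nM in this assay. Compound 2, `Cc1ccc(NC(=O)Nc2ncnc3c2nc(-c2ccco2)n3C)cc1`, is built on the same core but carries a larger substituent ending in a 4-methylphenyl group. For compound 2 this assay returns only a limit, > 30000 nM. That reading is the limit of > 30000 nM in this assay, at which 1 of the 2 values shown sits, so compound 2 stands at the weak end of the numbers shown, with no number of its own to place it more closely. Compound 3, `Cn1c(-c2ccco2)nc2c(NC(=O)Nc3ccccc3)ncnc21`, has not yet been measured in this assay. It differs from compound 2 in one place: hydrogen in place of methyl on an aromatic carbon, so that 4-methylphenyl becomes phenyl and (4-methylphenyl)amino becomes anilino. Going by the values given here, no measured pair shows the loss of this methyl, so the size of such a step is not known from these data. With so small a change, the step expected is an at least 1.2-fold lower number from compound 2 to compound 3 (0.07 log units; that floor lies within the scatter), none beyond the usual scatter. Compound 3 is accordingly estimated at 25000 nM, within a range from 4000 nM to 100000 nM, with a fair chance that this assay again reports only a limit.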

Compound 3, inhibition constant: 6250 nM
The estimate for compound 3 lay 4.0-fold (0.60 log units) above the measured number; the range from low to high includes it.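

In this assay, hydrogen in place of methyl on an aromatic carbon, para to a large group, amounts to an at least 4.8-fold lower number from compound 2 to compound 3 (0.68 log units; beyond the scatter), so even the loss of this single carbon from the 4-methylphenyl group changes the read-out at this position. The change also gives the series a number where it had none, with compound 3, the phenyl compound, at 6250 nM. The step can be given only as a lower bound, and its full size stays unknown because compound 2 is held by a limit and not by a number: the limit of > 30000 nM in this assay, at which 1 of the 3 values shown sits.

The compounds shown place nothing but hydrogen and methyl on this carbon, so it remains open how a chlorine, a methoxy group or an amine would read there, or a methyl moved elsewhere on the same ring. They also leave open whether the step would keep its size with a longer chain in place of the other methyl that compound 2 and compound 3 both carry.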